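The source may hold more compounds than are shown below. What is called first, only, known or untested is meant among the compounds shown, and "the series" means these compounds.

In a functional assay on HeLa cells (Homo sapiens) for cytotoxicity, read by WST assay, with a stated time of 48 h (on this read-out lower numbers stand for stronger inhibition and higher numbers for weaker inhibition), compound 1 `COC[C@H](C)[C@H](C)C(c1ccc(O)c(OC)c1)c1ccc(O)c(OC)c1` gives 72000 nM, compound 2 `COc1cc(C(c2ccc(O)c(OC)c2)[C@H](C)C(C)C)ccc1O` gives 16000 nM and compound 3 `COc1cc(C(c2ccc(O)c(OC)c2)[C@H](CF)C(C)C)ccc1O` gives 19000 nM. Compound 3 therefore stands within the scatter of compound 2 and clearly lower than compound 1. Compound 4 `COC[C@@H](C)[C@@H](C)C(c1ccc(O)c(OC)c1)c1ccc(O)c(OC)c1` makes one change to compound 3: 2-(methoxymethyl)-1-methylpropyl in place of 1-(fluoromethyl)-2-methylpropyl on a saturated chain carbon bound to two aromatic carbons. For the measured compounds named here, the entering group has the same name as the one in compound 1, but its stereocentres are drawn the opposite way. The closest evidence is a 3.8-fold lower number from compound 1 to compound 3 (0.58 log units; beyond the scatter), and a 4.5-fold lower number from compound 1 to compound 2 (0.65 log units; beyond the scatter) is similar, whereas a 1.2-fold higher number from compound 2 to compound 3 (0.07 log units; within the scatter) stays within the scatter. Running the first of these backwards suggests a modest rise in this assay, although no measured compound shows what the opposite stereocentres do. The expected step is a 2.6-fold higher number from compound 3 to compound 4 (0.42 log units; beyond the scatter). For compound 4 the estimated value is 50000 nM, with a range of 18000 nM to 120000 nM.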

Compound 4, half-maximal inhibitory concentration: > 100000 nM
Compound 4 was reported as a limit; the forecaster's own chance of this, stated with the estimate: 10%; at least 2.0-fold (0.30 log units) between middle value and limit.
By their numbers in this assay, from the lowest: compounds 2 and 3 (each within the scatter of the next); then compound 1. At a limit, above all of these: compound 4.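

In this assay, compound 4 is reported only as a limit, > 100000 nM. With the 2-(methoxymethyl)-1-methylpropyl group in this place, the number moves well away from the fluorinated and unsubstituted chains, with an at least 5.2-fold higher number from compound 3 to compound 4 (0.72 log units; beyond the scatter) and an at least 6.2-fold higher number from compound 2 to compound 4 (0.79 log units; beyond the scatter). Inverting both stereocentres gives an at least 1.3-fold higher number from compound 1 to compound 4 (0.14 log units; that floor lies within the scatter), so these data do not establish any effect of configuration.

As far as these compounds go, how a hydroxyl group or an amine in place of the methoxy would behave remains open. So does the true value of compound 4 beyond its limit.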